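The source may hold more compounds than are shown below. What is called first, only, known or untested is meant among the compounds shown, and "the series" means these compounds.

Measured compounds, values in an assay on CHO cells for displacement of a labelled ligand from adenosine receptor A1 (Homo sapiens), read by scintillation counting, with a stated time of 120 min, tested at 1 uM; on this read-out higher numbers stand for more inhibition at the one concentration tested (going by the name of the read-out) and lower numbers for less inhibition:

compound 1 `Cc1nc2sc(-c3ccc(O)cc3)nc2c(=O)[nH]1` gives 1%
compound 2 `Cc1nc2sc(-c3ccco3)nc2c(=O)[nH]1` gives 37%
compound 3 `Cc1nc2sc(-c3cccs3)nc2c(=O)[nH]1` gives 4%

Compound 3 stands second highest of the three numbers in this assay. Its nearest neighbour is compound 1, whose value sits within the scatter of that of compound 3, so no order between the two can be claimed. Among the compounds with values here, the only compound clearly apart is compound 2, and the one step measured in one place is a number 33 percentage points lower from compound 2 to compound 3 (beyond the scatter), a large loss when thiophen-2-yl replaced furan-2-yl on the aromatic carbon.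

Compound 4 `Cc1nc2sc(-n3cccc3)nc2c(=O)[nH]1` is not yet measured. It differs from compound 3 by 1H-pyrrol-1-yl in place of thiophen-2-yl on an aromatic carbon. Within the data shown here, no measured step covers a pyrrole ring or a ring attached through its nitrogen, so the step from compound 3 to compound 4 has no direct precedent. Among the measured compounds shown here, what the series shows is that a furan-2-yl at this place gave the only value clearly above the rest, while thiophen-2-yl and the hydroxyphenyl of compound 1 both gave low numbers. With a low starting value and a change without precedent, a step within the scatter is expected, a number 6 percentage points higher from compound 3 to compound 4 (within the scatter), with a wide range allowed for the possibility that a new five-membered ring behaves more like that of compound 2. Compound 4 is therefore estimated at 10%, between 0% and 35%.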

Compound 4, a percentage reported as inhibition, at one concentration (the size of the read-out at that concentration, not a potency): 1%
Estimate against measurement, compound 4: 9 percentage points above; measured number inside the range.
By their numbers in this assay, from the lowest: compounds 1, 4 and 3 (each within the scatter of the next); then compound 2.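

In this assay, a number 3 percentage points lower from compound 3 to compound 4 (within the scatter), so replacing thiophen-2-yl with 1H-pyrrol-1-yl on this aromatic carbon, with the same counts of heavy atoms, donors and acceptors, leaves the read-out unresolved from that of compound 3. Against the furan-2-yl group, a number 36 percentage points lower from compound 2 to compound 4 (beyond the scatter), so furan-2-yl now stands clearly apart from two other five-membered aromatic rings with one hetero atom, and not only from thiophen-2-yl; having such a ring at this place is therefore not enough to give the value of compound 2. Nothing available explains why furan-2-yl differs from thiophen-2-yl and 1H-pyrrol-1-yl here.

Going by these compounds, it remains open whether the higher number depends on furan-2-yl itself, which furan-3-yl, an oxazole ring or a furan-2-yl carrying a methyl or a carboxylic acid could test, and whether the number is higher, lower or level with a non-aromatic group such as morpholine or a simple amine on this carbon. On these data alone, with readings at one concentration only, compound 2 at 37% gives the size of the inhibition at that concentration, and its potency remains open.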